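A few compounds are considered here, and "the series" means these few. Any claim that something is new, unique, unknown or untested is made for them only; others in the source may bear on it.

Measured compounds:
compound 1 `O=C(CBr)Nc1ccc(C(=O)/C=C/c2ccco2)cc1` gives 25%
compound 2 `O=C(CO[N+](=O)[O-])Nc1ccc(C(=O)/C=C/c2ccco2)cc1` gives 39%
compound 3 `COc1ccc(/C=C/C(=O)c2ccc(NC(=O)C(C)O[N+](=O)[O-])cc2)cc1` gives 35%

In a functional assay on the whole organism (strain albino) for inhibition, with Rattus norvegicus as the target, read by paw edema, with stated times of 30 min and 5 h, at a dose of 100 mg/kg by the oral route (a lower number here means less inhibition, a higher number more inhibition at the dose given (going by the name of the read-out)), compound 3 stands second highest of the three numbers. Its nearest neighbour is compound 2, whose value of 39% lies within the scatter of compound 3, and the furthest is compound 1, whose value of 25% also lies within the scatter, so no order among the three can be claimed.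

Compound 4 `CC(O[N+](=O)[O-])C(=O)Nc1ccc(C(=O)/C=C/c2ccco2)cc1` has not yet been measured. It differs from compound 3 by furan-2-yl in place of 4-methoxyphenyl on a double-bonded chain carbon bound to a double-bonded chain carbon. Within the data shown here, the only measured step, a number 14 percentage points higher from compound 1 to compound 2 (beyond the scatter), concerns a change on the saturated chain carbon bound to the carbonyl carbon and does not bear on an exchange of the aromatic group on the double-bonded chain. Compound 2 and compound 3 differ in two places, so their values only show that both sit within the scatter of each other. Among the measured compounds shown here, with no step in this assay that speaks to the change, no shift beyond the scatter is expected, and a number 2 percentage points higher from compound 3 to compound 4 (within the scatter) is the estimated step. Compound 4 is therefore expected to give about 37% in this assay, between 26% and 48%.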

Compound 4, a percentage reported as inhibition, in the whole organism at one dose (the size of the read-out at that dose, not a potency): 49%
Beside the measured number, compound 4's estimate is 12 percentage points below it; the whole stated range lies below it.
By their numbers in this assay, from the lowest: compounds 1, 3, 2 and 4 (each within the scatter of the next, the first and the last beyond it).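

In this assay, among these compounds, furan-2-yl in place of 4-methoxyphenyl on a double-bonded chain carbon bound to a double-bonded chain carbon gives a number 14 percentage points higher from compound 3 to compound 4 (beyond the scatter) and so shows, for the first time, that the aromatic group at this position changes the inhibition of paw edema. At the other changed site, methyl in place of hydrogen gives a number 10 percentage points higher from compound 2 to compound 4 (within the scatter) with no shift that can be told from the scatter, while 1-(nitrooxy)ethyl in place of bromomethyl on a carbonyl carbon gives a number 24 percentage points higher from compound 1 to compound 4 (beyond the scatter) and widens the range seen in this series. Nothing measured here accounts for the gain with furan-2-yl.

As far as these compounds go, this exchange rests on a single pair, so it remains open whether the step would also appear with bromomethyl on the carbonyl carbon. Also open, from the compounds shown here alone, is how a thiophen-2-yl, a pyridin-3-yl or an unsubstituted phenyl ring would compare at the same position.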